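Working notes: from compound 3 to compound 4

The source may hold more compounds than are shown below. What is called first, only, known or untested is meant among the compounds shown, and "the series" means these compounds.

Measured so far:
- compound 1, `O=C(CSc1nc(Nc2ccccc2)c2ccccc2n1)Nc1cccc(Br)c1`, gives 9620 nM in a functional assay on MGC-803 cells (Homo sapiens) for inhibition, read by MTT assay, with a stated time of 72 h; on this read-out higher numbers stand for weaker inhibition and lower numbers for stronger inhibition
- compound 2, `O=C(CSc1nc(Nc2ccccc2)c2ccccc2n1)Nc1ccc(F)c(Cl)c1`, gives 20900 nM
- compound 3, `C=CC(=O)Nc1cccc(NC(=O)CSc2nc(Nc3ccccc3F)c3ccccc3n2)c1`, gives 26100 nM

Compound 3 holds the highest of the three numbers. Its gap to compound 2 lies within the scatter, so no order between the two is claimed; its gap to compound 1 lies beyond the scatter, so compound 1 stands as the stronger inhibitor of that pair.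

Compound 4, `C=CC(=O)Nc1cccc(NC(=O)CSc2nc(Nc3ccc(C(F)(F)F)cc3)c3ccccc3n2)c1`, differs from compound 3 by 4-(trifluoromethyl)phenyl in place of 2-fluorophenyl on a nitrogen on an aromatic ring. Within the data shown here, the only measured step, a 2.2-fold higher number from compound 1 to compound 2 (0.34 log units; beyond the scatter), concerns an exchange on an amide-type nitrogen, a different place from the nitrogen on an aromatic ring that changes here. Among the measured compounds shown here, no measured step touches that position, so no measured step bears directly on the present change.

With nothing to point either way, no step beyond the scatter is expected from compound 3 to compound 4: a 1.0-fold lower number from compound 3 to compound 4 (0.02 log units; within the scatter). Compound 4 is therefore estimated at 25000 nM in this assay, with a range from 8000 nM to 80000 nM.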

Compound 4, half-maximal inhibitory concentration: 12100 nM
Compound 4: middle estimate off by 2.1-fold (0.32 log units), on the high side; the measured number falls inside the stated range.
By their numbers in this assay, from the lowest: compounds 1, 4, 2 and 3 (each within the scatter of the next, the first and the last beyond it).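

In this assay, among these compounds, a 2.2-fold lower number from compound 3 to compound 4 (0.33 log units; beyond the scatter) is the first measured step at this position, and it lies beyond the scatter. The aryl group on this nitrogen therefore moves the number, and the direction favours 4-(trifluoromethyl)phenyl over 2-fluorophenyl, at least with the rest of compound 3 held constant. No evidence is available to explain this shift.

The exchange changes both the substituent and its printed ring position, so these two contributions cannot be separated from this single step, and it remains unclear whether the same exchange would give a similar step with the other amide-side groups seen in the series. From the compounds shown here alone, it is also open how this position would respond to groups of a different kind, such as a methoxy group or an amine on the phenyl ring, or a pyridine ring in its place.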